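Swapping chloro for methyl on a weak inhibitor

A few compounds are considered here, and "the series" means these few. Any claim that something is new, unique, unknown or untested is made for them only; others in the source may bear on it.

In a functional assay on L1210 cells (Mus musculus) for antiproliferative activity, with a stated time of 48 h (a higher number here means a weaker inhibitor, a lower number a stronger inhibitor), compound 1 (`C=C(Br)C(=O)Nc1ccc(/C=C/C(=O)c2ccc(C)cc2)cc1`) gives 1900 nM as its half-maximal inhibitory concentration. In this assay compound 2 (`Nc1ccc(/C=C/C(=O)c2ccc(Cl)cc2)cc1`) gives 111000 nM (the higher of the two numbers), which makes it the weaker inhibitor, and the gap lies beyond the usual scatter. These two compounds differ in more than one place, so their gap cannot be pinned on any single change. Compound 3 (`Cc1ccc(C(=O)/C=C/c2ccc(N)cc2)cc1`) departs from compound 2 by one swap (methyl in place of chloro on an aromatic carbon): methyl in place of chloro on an aromatic carbon. Among the compounds with values here, no measured pair shows this swap alone. The expectation in this assay is therefore a modest one, with no step beyond the scatter in either direction. Only a small step is expected (a 1.1-fold lower number from compound 2 to compound 3 (0.05 log units; within the scatter)). Compound 3 is expected at about 100000 nM (estimated range 40000 nM to 250000 nM).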

Compound 3, half-maximal inhibitory concentration: 49000 nM
Compound 3: the middle estimate sits 2.0-fold (0.31 log units) above what was measured; low and high end bracket the measured number.
By their numbers in this assay, from the lowest: compound 1; then compound 3; then compound 2.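

In this assay, methyl in place of chloro on an aromatic carbon, para to a large group, gives a 2.3-fold lower number from compound 2 to compound 3 (0.36 log units; beyond the scatter), so this one swap moves the number beyond the scatter, though only modestly. Within the data shown here, compound 3 also gives the first single-change comparison with compound 1: hydrogen in place of (1-bromoethenyl)carbonyl on the nitrogen corresponds to a 26-fold higher number from compound 1 to compound 3 (1.41 log units; beyond the scatter), a much larger step than the swap of chloro for methyl. Nothing available explains either step.

As far as these compounds go, it remains open whether the swap of chloro for methyl would give a similar step with (1-bromoethenyl)carbonyl on the nitrogen, as only compound 1 carries that group here. From the compounds shown here alone, how a fluoro, a methoxy or a plain hydrogen at the same ring position would compare also remains unknown.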